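Swapping a Cyanophenyl for an Aminopyridine on a Shared Core

This account rests on a few compounds, and the source may have more. Where it says the series, first, only, none or still open, it means among the compounds named here.

compound 1, `N#Cc1ccccc1-c1cc(F)cc(-n2nnc(-c3ccccn3)n2)c1`: 4 nM
compound 2, `Cc1ccc(-c2cc(F)cc(-n3nnc(-c4ccccn4)n3)c2)cn1`: 36 nM

Both compounds were measured in an assay for binding affinity to metabotropic glutamate receptor 5 (Rattus norvegicus); a higher number here means a weaker inhibitor, a lower number a stronger inhibitor. Compound 1 stands at the lowest of the two numbers; its nearest neighbour, compound 2, shows a 9.0-fold higher number from compound 1 to compound 2 (0.95 log units; beyond the scatter). Compound 3, `Nc1cccnc1-c1cc(F)cc(-n2nnc(-c3ccccn3)n2)c1`, has not yet been measured. It differs from compound 1 in one place: 3-aminopyridin-2-yl in place of 2-cyanophenyl on an aromatic carbon. For the measured compounds named here, only one measured step bears on this change: it exchanged the same 2-cyanophenyl for 6-methylpyridin-3-yl and gave a 9.0-fold higher number from compound 1 to compound 2 (0.95 log units; beyond the scatter). Compound 3 likewise loses the 2-cyanophenyl, and the entering 3-aminopyridin-2-yl is not the group seen in compound 2, so only the direction and rough size of that step can be carried over. For compound 3 the expected step is a 5.0-fold higher number from compound 1 to compound 3 (0.70 log units; beyond the scatter). Compound 3 is therefore estimated at 20 nM in this assay, with a range from 5 nM to 80 nM.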

Compound 3, inhibition constant: 31 nM
Estimate against measurement, compound 3: 1.6-fold (0.19 log units) below, within the range that was stated.
By their numbers in this assay, from the lowest: compound 1; then compounds 3 and 2 (each within the scatter of the next).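

Putting 3-aminopyridin-2-yl on this aromatic carbon in place of the 2-cyanophenyl gives a 7.8-fold higher number from compound 1 to compound 3 (0.89 log units; beyond the scatter) in this assay and shows that a second, differently built replacement also binds more weakly than compound 1. The two replacements cannot be told apart: 3-aminopyridin-2-yl in place of 6-methylpyridin-3-yl gives a 1.2-fold lower number from compound 2 to compound 3 (0.06 log units; within the scatter) even though one ring carries an amine and the other a methyl. Nothing available explains why either replacement is weaker than the 2-cyanophenyl.

From the compounds shown here alone, it remains open whether a plain phenyl, or a phenyl carrying an amine instead of the nitrile, would stay close to compound 1 or fall with compounds 2 and 3. A pyridine ring carrying a nitrile would also help separate the effect of adding a ring nitrogen from that of losing the nitrile.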